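A few compounds are considered here, and "the series" means these few. Any claim that something is new, unique, unknown or untested is made for them only; others in the source may bear on it.

Working notes on the series, cytotoxicity. Among the measured compounds shown here, in an ADME assay on A549 cells (Homo sapiens) for cytotoxicity, read by resazurin assay, with a stated time of 48 h (on this read-out higher numbers stand for lower toxicity in this test and lower numbers for higher toxicity in this test), compound 3 `O=C(Nc1ccc(NCc2cccc(C(F)(F)F)c2)cc1Cl)c1cc(Cl)ccc1O` gives 13300 nM, the lowest of the three numbers so far, though not clearly separated from all of them. Compound 1 `CCCNc1ccc(NC(=O)c2cc(Cl)ccc2O)c(Cl)c1` gives 22500 nM, and the change is a 1.7-fold lower number from compound 1 to compound 3 (0.23 log units; within the scatter), so these two cannot be ranked. Compound 2 `CC(C)CNc1ccc(NC(=O)c2cc(Cl)ccc2O)c(Cl)c1` gives 60000 nM, and the change is a 4.5-fold lower number from compound 2 to compound 3 (0.65 log units; beyond the scatter).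

Compound 4 `O=C(Nc1ccc(NCc2cnccc2Cl)cc1Cl)c1cc(Cl)ccc1O`, not yet measured in this assay, carries 4-chloropyridin-3-yl in place of 3-(trifluoromethyl)phenyl on a saturated chain carbon bound to a nitrogen on an aromatic ring.

For the measured compounds named here, no measured step exchanges one aromatic group for another, so the evidence is indirect. The two steps at this same place are those already given, one within the scatter and one modest. The remaining step, a 2.7-fold higher number from compound 1 to compound 2 (0.43 log units; beyond the scatter), is also modest and lies on the chain. From the compounds shown here alone, all measured steps at this place are therefore small, and the pyridine-bearing group itself is untested. No step beyond the scatter is expected, with a slight lean towards a higher number: the estimated step is a 1.4-fold higher number from compound 3 to compound 4 (0.13 log units; within the scatter). For compound 4 the expected value is 18000 nM, with an estimated range from 7000 nM to 45000 nM.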

Compound 4, half-maximal cytotoxic concentration: 126000 nM
Estimate against measurement, compound 4: 7.0-fold (0.85 log units) below; measured number outside the range, above it.
By their numbers in this assay, from the lowest: compounds 3 and 1 (each within the scatter of the next); then compound 2; then compound 4.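

At this place, on a saturated chain carbon bound to a nitrogen on an aromatic ring, the exchange of one aromatic group for another is the largest change seen so far in this assay (a 9.5-fold higher number from compound 3 to compound 4 (0.98 log units; beyond the scatter)), so the number depends on which aromatic group is present and not merely on there being one. The 4-chloropyridin-3-yl group also separates from both saturated groups (a 5.6-fold higher number from compound 1 to compound 4 (0.75 log units; beyond the scatter); a 2.1-fold higher number from compound 2 to compound 4 (0.32 log units; beyond the scatter)), whereas 3-(trifluoromethyl)phenyl could not be ranked against ethyl and gave a lower number than isopropyl, which places the two aromatic groups on opposite sides of the saturated ones. Nothing available explains this step, and this single exchange cannot assign it to the ring nitrogen, the chlorine or the departure of trifluoromethyl.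

From the compounds shown here alone, it remains open whether pyridin-3-yl or 4-chlorophenyl at this place, each carrying only one of the two new features, would read with compound 3 or with compound 4. Also open, going by these compounds, is how an aminomethyl or a carboxylic acid group on the aromatic ring, or a longer chain in place of ethyl, would read in this assay.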